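The source may report more compounds than this note shows. Statements on the series, on what has been measured and on what is new or still open speak of the compounds shown alone.

Series notes, shared core as in compound 1 `CCCn1nc(C(=O)N[C@H]2COc3ccccc3N(C)C2=S)nc1Cc1ccccc1` and compound 2 `CN1C(=S)[C@@H](NC(=O)c2nc(Cc3ccccc3)n(C3COC3)n2)COc2ccccc21`; the two differ only at the aromatic nitrogen that carries the variable group. In a functional assay on HT-29 cells (Homo sapiens) for inhibition, read by luminescence and CellTiter-Glo, with a stated time of 24 h (on this read-out lower numbers stand for an effect already at smaller amounts and higher numbers for an effect only at larger amounts of compound), compound 1 gives 288 nM, and compound 2 gives 916 nM. Among the measured compounds shown here, the one step measured so far, a 3.2-fold higher number from compound 1 to compound 2 (0.50 log units; beyond the scatter), is the only guide available. For the measured compounds named here, compound 2 therefore stands at the highest of the two numbers in this assay, with compound 1 as its only neighbour.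

Compound 3 `Cc1cnc(-n2nc(C(=O)N[C@H]3COc4ccccc4N(C)C3=S)nc2Cc2ccccc2)nc1` is not yet measured in this assay. Its change from compound 2: 5-methylpyrimidin-2-yl in place of oxetan-3-yl on an aromatic nitrogen. Going by the values given here, no measured step covers an aromatic group at this aromatic nitrogen, so the expectation rests on the single step from propyl to oxetan-3-yl and on the fact that the two measured groups sit within a modest spread of each other. The expected step for compound 3 is a 1.8-fold lower number from compound 2 to compound 3 (0.26 log units; within the scatter), with direction uncertain and a wide range. Compound 3 is estimated at 500 nM in this assay, within 120 nM to 2500 nM.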

Compound 3, half-maximal effective concentration: 1950 nM
For compound 3 the middle estimate is 3.9-fold (0.59 log units) below the measured one, and the stated range covers the measured number.
By their numbers in this assay, from the lowest: compound 1; then compound 2; then compound 3.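

In this assay, the aromatic nitrogen of the five-membered ring now carries an aromatic group, and the number rises further, a 2.1-fold higher number from compound 2 to compound 3 (0.33 log units; beyond the scatter), while the whole span is a 6.8-fold higher number from compound 1 to compound 3 (0.83 log units; beyond the scatter). Among these three compounds, the open chain propyl gives the lowest number, and both ring-bearing groups stand higher, with the seven-heavy-atom 5-methylpyrimidin-2-yl above the four-heavy-atom oxetan-3-yl; compound 3 still gives a measurable effect, so this place accepts a six-membered aromatic ring, though at a cost in the number relative to compound 1. No supporting measurement is available to account for either step.

The three groups differ in ring presence, aromaticity and heavy-atom count together, so the contribution of each remains unresolved, and the role of the methyl on the pyrimidine cannot be separated from that of the ring. Open questions are how a longer chain such as butyl, a plain phenyl ring, an unsubstituted pyrimidin-2-yl or a chain ending in an amine or a carboxylic acid would compare with propyl at this nitrogen.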